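Compound 3 at the limit, and a 3-methoxyphenyl swap

This account rests on a few compounds, and the source may have more. Where it says the series, first, only, none or still open, it means among the compounds named here.

In an ADME assay on MRC5 cells (Homo sapiens) for cytotoxicity, read by fluorescence and resazurin assay, with a stated time of 3 days (a lower number here means a stronger inhibitor, a higher number a weaker inhibitor), compound 1 `Cc1cn(C2CCN(Cc3cccc(Oc4ccc(Cl)cc4)c3)CC2)c(=O)[nH]c1=O` gives 25100 nM. Compound 2 `Cc1cn(C2CCN(Cc3cncc(Oc4cccc(Cl)c4)c3)CC2)c(=O)[nH]c1=O` reads > 64000 nM, which is a limit and not a number. Compound 3 `Cc1cn(C2CCN(Cc3cccc(Oc4ccc(F)c(F)c4)c3)CC2)c(=O)[nH]c1=O` reads > 64000 nM, again a limit and not a number. Compound 3 thus has no exact value and stands at the limit of > 64000 nM in this assay, at which 2 of the 3 values shown sit.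

Compound 4 `COc1cccc(Oc2cccc(CN3CCC(n4cc(C)c(=O)[nH]c4=O)CC3)c2)c1` carries 3-methoxyphenyl in place of 3,4-difluorophenyl on an oxygen on an aromatic ring. One measured step changes the group at this same place: an at least 2.5-fold higher number from compound 1 to compound 3 (0.40 log units; beyond the scatter), with 3,4-difluorophenyl in place of 4-chlorophenyl. Going by these compounds, that step starts from a number and ends at a limit, so its true size is unknown. Among the measured compounds shown here, with only this step to go on, a small move to a lower number in this assay is expected, and it may not exceed the scatter. The expected change is an at least 1.2-fold lower number from compound 3 to compound 4 (0.10 log units; that floor lies within the scatter). For compound 4 the estimated value is 50000 nM, with an expected range of 20000 nM to 100000 nM.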

Compound 4, half-maximal inhibitory concentration: 25300 nM
Compound 4: the middle estimate sits 2.0-fold (0.30 log units) above what was measured; low and high end bracket the measured number.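

In this assay, 3-methoxyphenyl in place of 3,4-difluorophenyl on the oxygen gives an at least 2.5-fold lower number from compound 3 to compound 4 (0.40 log units; beyond the scatter). Against 4-chlorophenyl at the same place, 3-methoxyphenyl gives a 1.0-fold higher number from compound 1 to compound 4 (0.00 log units; within the scatter), so these two groups are not told apart here, and among compound 1, compound 3 and compound 4 only the 3,4-difluorophenyl group stands apart. Going by these compounds, the true size of that separation stays unknown, as compound 3 sits at a limit and not at a number: the limit of > 64000 nM in this assay, at which 2 of the 4 values shown sit.

The compounds shown leave open whether a 4-fluorophenyl or a 4-methoxyphenyl on the same oxygen would read like compound 1 or like compound 3. Compound 2 differs from the others in more than one place and cannot settle this.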